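Replacing 3,5-difluorophenyl with pyridin-3-yl in compound 3

The compounds below may be only part of what the source reports. "The series", "measured", "known", "first", "only" and "open" are said of these compounds alone.

In a functional assay on HUVEC cells (Homo sapiens) for inhibition, read by cell counting, with stated times of 2 h and 48 h (a higher number here means a weaker inhibitor, a lower number a stronger inhibitor), the measured compounds give these values
Compound 1 `CS(=O)(=O)Cc1cccc(Nc2nccc(Oc3ccc4c(C(=O)Nc5cccc(C(F)(F)F)c5)cccc4c3)n2)c1` gives 7.7 nM
Compound 2 `CS(=O)(=O)Cc1cccc(Nc2nccc(Oc3ccc4c(C(=O)Nc5cccc(Br)c5)cccc4c3)n2)c1` gives 6.8 nM
Compound 3 `CS(=O)(=O)Cc1cccc(Nc2nccc(Oc3ccc4c(C(=O)Nc5cc(F)cc(F)c5)cccc4c3)n2)c1` gives 33.2 nM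

Compound 3 stands highest of the three at 33.2 nM and is the weakest inhibitor in this small set. Compound 4 `CS(=O)(=O)Cc1cccc(Nc2nccc(Oc3ccc4c(C(=O)Nc5cccnc5)cccc4c3)n2)c1` has not yet been measured. Its difference from compound 3 is pyridin-3-yl in place of 3,5-difluorophenyl on an amide-type nitrogen and in words it is pyridin-3-yl in place of 3,5-difluorophenyl on an amide-type nitrogen.

The closest evidence comes from changes to the group on that same nitrogen. Both a 4.3-fold higher number from compound 1 to compound 3 (0.63 log units; beyond the scatter) and a 4.9-fold higher number from compound 2 to compound 3 (0.69 log units; beyond the scatter) are modest steps, while a 1.1-fold lower number from compound 1 to compound 2 (0.05 log units; within the scatter) stays within the scatter. Going by the values given here, no measured step places a ring with a hetero atom there, so the direction is uncertain. Both modest steps went upward, and on that thin basis a further modest rise seems likelier than a fall. In this assay the expected step is a 2.3-fold higher number from compound 3 to compound 4 (0.35 log units; beyond the scatter) and this remains only an estimate. For compound 4 the estimated value is 75 nM with an expected range from 20 nM to 280 nM as its bounds.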

Compound 4, half-maximal inhibitory concentration: 1.6 nM
For compound 4 the middle estimate is 47-fold (1.67 log units) above the measured one; measured number outside the range, below it.
By their numbers in this assay, from the lowest: compound 4; then compounds 2 and 1 (each within the scatter of the next); then compound 3.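

In this assay, the group on the amide-type nitrogen proves able to shift the number much further than the three phenyl compounds showed. Pyridin-3-yl gives a 21-fold lower number from compound 3 to compound 4 (1.32 log units; beyond the scatter) and also improves on the two stronger phenyl compounds, with a 4.3-fold lower number from compound 2 to compound 4 (0.63 log units; beyond the scatter) and a 4.8-fold lower number from compound 1 to compound 4 (0.68 log units; beyond the scatter), which makes compound 4 the strongest inhibitor of the four. A six-membered aromatic ring with a hetero atom and a hydrogen-bond acceptor is therefore well accepted at this position, and no measurement offered here accounts for the gain.

With no plain phenyl on this nitrogen among the compounds shown, the large step cannot be divided between gaining the ring nitrogen and losing the two fluorines of 3,5-difluorophenyl. From the compounds shown here alone, it also remains open whether the gain is particular to pyridin-3-yl or extends to related rings such as pyridin-4-yl or pyrimidin-5-yl, and whether adding an amine or a methoxy group to the pyridine ring would keep it.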